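The compounds below may be only part of what the source reports. "The series", "measured", "known", "first", "only" and "open" are said of these compounds alone.

Compound 2: `CCn1c(C(=O)NCCCN(C)C)ccc1C(CC)(CC)c1ccc(OCC(O)C(C)(C)C)c(C)c1`, 37 nM
Compound 1: `C=CCN(C)C(=O)c1ccc(C(CC)(CC)c2ccc(OCC(=O)C(C)(C)C)c(C)c2)n1CC`, 21600 nM

In an assay on HL-60 cells for agonist activity at vitamin D3 receptor (Homo sapiens), read by microscopy, with a stated time of 96 h (on this read-out lower numbers stand for an effect already at smaller amounts and higher numbers for an effect only at larger amounts of compound), compound 2 gives 37 nM, the lowest of the two numbers measured here. Compound 1 gives 21600 nM in this assay, a far higher number; the gap between the two lies well beyond the scatter. Compound 1 and compound 2 differ from each other in more than one place, so these two values alone do not tell which part of the difference carries the gap.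

Compound 3, `C=CCN(C)C(=O)c1ccc(C(CC)(CC)c2ccc(OCC(O)C(C)(C)C)c(C)c2)n1CC`, has not yet been measured. Going from compound 2 to compound 3 changes one place: allyl(methyl)amino in place of (3-(dimethylamino)propyl)amino on a carbonyl carbon. For the measured compounds named here, no measured pair shows this change on its own. Because compound 1, which carries the same allyl(methyl)amino group, gives 21600 nM, while compound 2 gives 37 nM, some loss is expected, but part of the gap between these two may belong to the other place where they differ. The expected step of an 8.1-fold higher number from compound 2 to compound 3 (0.91 log units; beyond the scatter) is therefore moderate, in the direction of a higher number. Compound 3 is expected to give about 300 nM in this assay, with a range from 40 nM to 3000 nM.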

Compound 3, half-maximal effective concentration: 3950 nM
The estimate for compound 3 lay 13-fold (1.12 log units) below the measured number, outside the stated range (above it).
By their numbers in this assay, from the lowest: compound 2; then compound 3; then compound 1.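

Measured on its own in this assay, replacing (3-(dimethylamino)propyl)amino with allyl(methyl)amino on the carbonyl carbon gives a 110-fold higher number from compound 2 to compound 3 (2.03 log units; beyond the scatter), so this single change is large and this position clearly matters on this read-out. The other place where compound 1 and compound 2 differ can now be read separately: 1-hydroxy-2,2-dimethylpropyl in place of (tert-butyl)carbonyl gives a 5.5-fold lower number from compound 1 to compound 3 (0.74 log units; beyond the scatter), a modest step that is smaller than the change on the carbonyl carbon. Nothing given here explains why either change has the size it does.

The groups exchanged on the carbonyl carbon differ in several ways at once, including the terminal dimethylamino, the amide hydrogen and the double bond of the allyl group, so the compounds shown do not reveal which of these features goes with the large step. A saturated propyl(methyl)amino group, or a (3-(dimethylamino)propyl)amino group with a methyl on its amide nitrogen, would help to separate these features.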